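The source may report more compounds than this note shows. Statements on the series, on what has been measured and on what is new or still open speak of the compounds shown alone.

Measured compounds:
- compound 1 `COc1ccc(Br)cc1S(=O)(=O)Nc1cc2c(cc1O)NC(=O)C(C)(C)O2`: in a functional assay on LNCaP cells (Homo sapiens) for antiproliferative activity, read by luminescence, with a stated time of 96 h (a higher number here means a weaker inhibitor, a lower number a stronger inhibitor), compound 1 gives 7700 nM
- compound 2 `CC1(C)Oc2cc(NS(=O)(=O)c3ccccc3)ccc2NC1=O`: compound 2 gives 7520 nM
- compound 3 `CC1(C)Oc2cc(NS(=O)(=O)C3CCCCC3)ccc2NC1=O`: compound 3 gives 8400 nM

All three compounds share the same bicyclic core and differ only in the group carried on the sulfonyl sulfur and, for compound 1, in an extra hydroxy on the core. The three numbers lie within the usual scatter of one another, so compound 1 cannot be placed above or below compound 2 or compound 3; its value simply sits with theirs.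

Compound 4 `COc1ccc(Br)cc1S(=O)(=O)Nc1ccc2c(c1)OC(C)(C)C(=O)N2` is the next compound. Compared with compound 1 the change is hydrogen in place of hydroxy on an aromatic carbon. For the measured compounds named here, the one measured step, a 1.1-fold higher number from compound 2 to compound 3 (0.05 log units; within the scatter), concerns the group on the sulfonyl sulfur and not the core, so it does not directly inform this change; it only shows that a change elsewhere left the number essentially unmoved. Going by the values given here, no measured compound tests the hydroxy itself. With nothing pointing in either direction, no step beyond the scatter is expected in this assay.

Compound 4 is therefore estimated at 7700 nM, with a range from 3500 nM to 17000 nM, which means an expected step of no change at the digits printed from compound 1 to compound 4 (within the scatter).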

Compound 4, half-maximal inhibitory concentration: 6280 nM
The estimate for compound 4 lay 1.2-fold (0.09 log units) above the measured number, within the range that was stated.
By their numbers in this assay, from the lowest: compounds 4, 2, 1 and 3 (each within the scatter of the next).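

In this assay, the hydroxy on this aromatic carbon, ortho to a large group, gives way to hydrogen with a 1.2-fold lower number from compound 1 to compound 4 (0.09 log units; within the scatter). For the compounds shown here, this is the first direct test of that position, as the earlier step concerned only the group on the sulfonyl sulfur. With the rest of the structure the same, the hydroxy and the hydrogen-bond donor and acceptor counted with it make no difference beyond the scatter in this antiproliferative read-out, and no further measurement here bears on that result.

Only hydroxy and hydrogen are shown at this position, so what a methoxy, an amine or a carboxylic acid would do there remains open. Also open, from the compounds shown here alone, is whether the hydroxy would give the same result alongside the phenyl of compound 2 or the cyclohexyl of compound 3.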